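The compounds below may be only part of what the source reports. "The series", "measured", "known", "first", "only" and "open" are said of these compounds alone.

Compound 2 `O=C(Nc1ccc(Oc2ccnc3[nH]ccc23)c(F)c1)c1cn(-c2ccc(F)cc2)c2ccccc2c1=O` gives 290 nM in a functional assay on A549 cells (Homo sapiens) for inhibition, read by MTT assay, with a stated time of 72 h (on this read-out higher numbers stand for weaker inhibition and lower numbers for stronger inhibition), and stands at one end of the two numbers shown. Compound 1 `O=C(Nc1ccc(Oc2ccnc3[nH]ccc23)cc1)c1cn(-c2ccc(Br)cc2)c2ccccc2c1=O` gives 450 nM in this assay, a gap to compound 2 that is within the scatter. Compound 3 `O=C(Nc1ccc(Oc2ccnc3[nH]ccc23)c(F)c1)c1cn(-c2ccc(Br)cc2)c2ccccc2c1=O` carries bromo in place of fluoro on an aromatic carbon. Within the data shown here, no measured pair isolates this change; compound 1 and compound 2 differ in two places and their values sit within the scatter of each other, so nothing beyond the scatter is expected in this assay. The expected step of a 1.2-fold higher number from compound 2 to compound 3 (0.08 log units; within the scatter) is small. Compound 3 is estimated at 350 nM, within 150 nM to 800 nM.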

Compound 3, half-maximal inhibitory concentration: 950 nM
Compound 3: the middle estimate sits 2.7-fold (0.43 log units) below what was measured; measured number above the stated range.
By their numbers in this assay, from the lowest: compounds 2 and 1 (each within the scatter of the next); then compound 3.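

In this assay, among these compounds, the change from 4-fluorophenyl to 4-bromophenyl gives a 3.3-fold higher number from compound 2 to compound 3 (0.52 log units; beyond the scatter) and weakens inhibition, the first single change that can be read at this position. With the bromo held in place, fluoro in place of hydrogen on an aromatic carbon gives a 2.1-fold higher number from compound 1 to compound 3 (0.32 log units; beyond the scatter) and also weakens inhibition. Nothing measured here accounts for either step.

Open, on these data alone, is how chloro, methyl or methoxy would compare with fluoro and bromo at this position. Also open, as far as these compounds go, is whether the fluoro step reads the same with 4-fluorophenyl in place.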